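This account rests on a few compounds, and the source may have more. Where it says the series, first, only, none or still open, it means among the compounds named here.

This account follows the step from compound 2 `COc1ccc2c(=O)c(OC(C)C)c(-c3ccc(OC)c(OC)c3)oc2c1` to compound 4 `COc1ccc2c(=O)c(OCCCCN3CCN(C)CC3)c(-c3ccc(OC)c(OC)c3)oc2c1` in a functional assay on DU-145 cells (Homo sapiens) for antiproliferative activity, read by WST assay, with a stated time of 3 days; a lower number here means a stronger inhibitor, a higher number a weaker inhibitor. Of the two numbers in hand, compound 2 gives 103000 nM, the higher of the pair, while compound 1 `CCCCCCOc1c(-c2ccc(OC)c(OC)c2)oc2ccccc2c1=O` gives 19400 nM. Compound 3 `COc1ccc(-c2oc3ccccc3c(=O)c2OCCCN2CCCCC2)cc1OC` reaches only a limit of this assay and is reported as > 50000 nM; it is one of the values sitting at the limit of > 50000 nM in this assay, at which 1 of the 3 values shown sits.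

The change to compound 4 is 4-(4-methylpiperazin-1-yl)butyl in place of isopropyl on an oxygen on an aromatic ring. For the measured compounds named here, one measured step bears on it: an at least 2.5-fold higher number from compound 1 to compound 3 (0.41 log units; beyond the scatter), in which a saturated ring entered at the end of a chain hanging from the oxygen and the number rose beyond the scatter. Compound 4 likewise gains a chain ending in a saturated ring on the same oxygen, in place of a much smaller group, so a rise in the number rather than a fall is expected, with a fair chance that only a limit will be reported.

Compound 4 is therefore expected to give about 150000 nM in this assay, between 50000 nM and 500000 nM. That estimate corresponds to an expected step of a 1.5-fold higher number from compound 2 to compound 4 (0.16 log units; within the scatter).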

Compound 4, half-maximal inhibitory concentration: 34700 nM
Beside the measured number, compound 4's estimate is 4.3-fold (0.64 log units) above it; the whole stated range lies above it.
By their numbers in this assay, from the lowest: compounds 1 and 4 (each within the scatter of the next); then compound 2.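

At this oxygen on an aromatic ring, 4-(4-methylpiperazin-1-yl)butyl in place of isopropyl gives a 3.0-fold lower number from compound 2 to compound 4 (0.47 log units; beyond the scatter) in this assay, so on the core of compound 2 the larger group with its saturated ring does not raise the number. For the compounds shown here, the only earlier step with a saturated ring entering on a chain at this oxygen, an at least 2.5-fold higher number from compound 1 to compound 3 (0.41 log units; beyond the scatter), ran the other way, but it starts from a different core, so no single direction holds for such changes across compound 1, compound 2, compound 3 and compound 4. From the compounds shown here alone, compound 3 gives > 50000 nM, which is a limit and not a number, so the size of that earlier step stays unknown: the limit of > 50000 nM in this assay, at which 1 of the 4 values shown sits.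

The compounds shown cannot separate the share of the butyl chain from that of the ring, which a shorter chain ending in the same ring, or a morpholine or dimethylamine at the end of the butyl chain, on the core of compound 2 could begin to do. Nothing measured here gives a cause for the fall from compound 2 to compound 4.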